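Series notes: compound 1, compound 2 and compound 3

The source may report more compounds than this note shows. Statements on the series, on what has been measured and on what is new or still open speak of the compounds shown alone.

Measured in a functional assay on CCRF-CEM cells (Homo sapiens) for antiproliferative activity, read by MTT assay, with a stated time of 96 h; on this read-out lower numbers stand for stronger inhibition and higher numbers for weaker inhibition:
- compound 1, `O=C1C2=C(C(=O)c3ncccc31)C1(CS2)NC(=O)N(c2ccccc2)C1=O`, 10 nM
- compound 2, `O=C1NC(=O)C2(CSC3=C2C(=O)c2ncccc2C3=O)N1`, 120 nM

Among the compounds with values here, compound 1 stands at the lowest of the two numbers; its nearest neighbour is compound 2, and the only measured step, a 12-fold higher number from compound 1 to compound 2 (1.08 log units; beyond the scatter), is large and beyond the scatter. That step is the hydrogen in place of phenyl on the amide-type ring nitrogen, so the phenyl region of the shared core is where the series has so far been probed.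

Compound 3, `CN(C)c1ccc(N2C(=O)NC3(CSC4=C3C(=O)c3ncccc3C4=O)C2=O)cc1`, keeps the phenyl and carries one further change relative to compound 1: dimethylamino in place of hydrogen on an aromatic carbon. Read one bond further out, the phenyl becomes 4-(dimethylamino)phenyl.

Within the data shown here, no measured step bears directly on a group added to that phenyl; the step from compound 1 to compound 2 only shows that the phenyl itself is not dispensable. Its removal is large, but there is nothing to say whether a substituent on it moves the number. The expectation for compound 3 is therefore a step within the scatter, a 1.2-fold higher number from compound 1 to compound 3 (0.08 log units; within the scatter), in no settled direction. The estimate for compound 3 in this assay is 12 nM, with a range from 4 nM to 40 nM.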

Compound 3, half-maximal inhibitory concentration: 1 nM
The estimate for compound 3 lay 12-fold (1.08 log units) above the measured number, and the stated range ends above it.
By their numbers in this assay, from the lowest: compound 3; then compound 1; then compound 2.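

Substitution on the phenyl is now shown to matter in this assay: dimethylamino in place of hydrogen on an aromatic carbon, para to a large group, gives a modest step beyond the scatter (a 10-fold lower number from compound 1 to compound 3 (1.00 log units; beyond the scatter)). The earlier pair showed only that losing the whole phenyl raises the number; this result shows that the ring also tolerates an added group there and that the number can still fall. Against the bare amide-type nitrogen, 4-(dimethylamino)phenyl gives a large step (a 120-fold lower number from compound 2 to compound 3 (2.08 log units; beyond the scatter)), which makes this ring nitrogen the most sensitive place probed so far in the series, though no evidence in hand explains the effect of the dimethylamino group.

The compounds shown leave open whether the step belongs to dimethylamino in particular or would also follow from another group on the same aromatic carbon, such as a primary amine, a methoxy group or a chlorine atom. They also leave open whether diethylamino or a ring amine such as morpholine would carry the number further or give it back.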